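This account rests on a few compounds, and the source may have more. Where it says the series, first, only, none or still open, it means among the compounds named here.

Measured in an ADME assay on the whole organism (strain CD-1) for pharmacokinetics, with Mus musculus as the target, at a dose of 3 mg/kg by the intravenous route; a higher number here means faster removal of the compound, a lower number slower removal:
- compound 1 `CN(Cc1ccccc1OCCCCCC(=O)O)C(=O)c1ccc(-c2ccco2)cc1`: 44 mL/min/kg
- compound 2 `C[C@@H](CCCOc1ccccc1CN(C)C(=O)c1ccc(-c2ccco2)cc1)CC(=O)O`: 1.3 mL/min/kg
- compound 3 `CN(Cc1ccccc1OCCC[C@@H]1C[C@H]1C(=O)O)C(=O)c1ccc(-c2ccco2)cc1`: 0.6 mL/min/kg

Of these three, compound 3 has the lowest number, at 0.6 mL/min/kg. Compound 4 `C/C(=C\CCCOc1ccccc1CN(C)C(=O)c1ccc(-c2ccco2)cc1)C(=O)O` has 2-carboxyprop-1-en-1-yl in place of 2-carboxycyclopropyl on a saturated chain carbon, three bonds along the chain from an oxygen on an aromatic ring. The three-membered ring is lost, so the end of the chain is open, as it is in the first two compounds.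

Two measured steps are large: a 34-fold lower number from compound 1 to compound 2 (1.53 log units; beyond the scatter) and a 73-fold lower number from compound 1 to compound 3 (1.87 log units; beyond the scatter). The third, a 2.2-fold lower number from compound 2 to compound 3 (0.34 log units; beyond the scatter), is modest and bears most directly on this change, since it also leads from an open chain to the ring. Going by the values given here, no measured compound carries the new unsaturated group, so the expectation is uncertain. A modest to moderate rise is expected, not a return to the level of the first compound. The expected change is a 5.0-fold higher number from compound 3 to compound 4 (0.70 log units; beyond the scatter). The estimated value for compound 4 is 3 mL/min/kg, within an expected range of 0.7 mL/min/kg to 15 mL/min/kg.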

Compound 4, clearance: 4 mL/min/kg
Estimate against measurement, compound 4: 1.3-fold (0.12 log units) below; measured number inside the range.
By their numbers in this assay, from the lowest: compound 3; then compound 2; then compound 4; then compound 1.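

Opening the three-membered ring into 2-carboxyprop-1-en-1-yl at this position raises the number in this assay (a 6.7-fold higher number from compound 3 to compound 4 (0.82 log units; beyond the scatter)), so the ring of compound 3 is not neutral here. A low number does not depend on that ring, however, since the open chain of compound 4 still stands well under the unbranched acid (an 11-fold lower number from compound 1 to compound 4 (1.04 log units; beyond the scatter)). Two open chains also differ from each other (a 3.1-fold higher number from compound 2 to compound 4 (0.49 log units; beyond the scatter)), so the form of the open chain end matters as well, and nothing given here explains these differences. On these data alone, whether the methyl or the double bond of 2-carboxyprop-1-en-1-yl sets the number of compound 4 remains open. So does whether a cyclobutane ring in place of the three-membered ring would keep the number as low as in compound 3.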